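Swapping Methyl for Nitro on the Aryl Ring

The source may report more compounds than this note shows. Statements on the series, on what has been measured and on what is new or still open speak of the compounds shown alone.

Measured compounds:
Compound 1 `O=[N+]([O-])c1ccc(-c2cn3nc(Cc4ccc(Cl)cc4)sc3n2)cc1` gives 214000 nM in a functional assay on L1210 cells (Mus musculus) for cytotoxicity, with a stated time of 48 h; on this read-out lower numbers stand for stronger inhibition and higher numbers for weaker inhibition.
Compound 2 `O=[N+]([O-])c1ccc(-c2nc3sc(Cc4ccc(Cl)cc4)nn3c2Br)cc1` gives 94000 nM in this assay.
Compound 3 `Cc1ccc(-c2nc3sc(Cc4ccc(Cl)cc4)nn3c2C=O)cc1` gives 23000 nM in this assay.

Compound 3 stands lowest of the three numbers: compound 2 sits higher and compound 1 higher still, both beyond the scatter. Compound 4 `O=Cc1c(-c2ccc([N+](=O)[O-])cc2)nc2sc(Cc3ccc(Cl)cc3)nn12` differs from compound 3 by nitro in place of methyl on an aromatic carbon. For the measured compounds named here, none of the measured steps covers this exchange; the only single-point step, a 2.3-fold lower number from compound 1 to compound 2 (0.36 log units; beyond the scatter), concerns bromo in place of hydrogen and says nothing about methyl against nitro. Compounds 1 and 2 both carry the nitro group and give higher numbers than compound 3, yet each also differs from it elsewhere, so they offer only a hint. A modest step upward in this assay, a 1.5-fold higher number from compound 3 to compound 4 (0.18 log units; within the scatter), is therefore expected for compound 4, with wide uncertainty. Compound 4 is estimated at 35000 nM, between 10000 nM and 120000 nM.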

Compound 4, half-maximal inhibitory concentration: 15000 nM
For compound 4 the middle estimate is 2.3-fold (0.37 log units) above the measured one, and the stated range covers the measured number.
By their numbers in this assay, from the lowest: compounds 4 and 3 (each within the scatter of the next); then compound 2; then compound 1.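

In this assay, a 1.5-fold lower number from compound 3 to compound 4 (0.19 log units; within the scatter) comes from nitro in place of methyl, so this position on the six-membered aromatic ring tolerates either group without a change beyond the scatter. With nitro kept, formyl on the other aromatic carbon matters far more: a 6.3-fold lower number from compound 2 to compound 4 (0.80 log units; beyond the scatter) follows from replacing bromo and a 14-fold lower number from compound 1 to compound 4 (1.15 log units; beyond the scatter) from replacing hydrogen. Nothing available explains these differences.

From the compounds shown here alone, whether an amine or a carboxylic acid in place of the nitro would hold the number, or a longer chain in place of the formyl would lower it further, remains open.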